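A few compounds are considered here, and "the series" means these few. Any claim that something is new, unique, unknown or untested is made for them only; others in the source may bear on it.

In a functional assay on Caco-2 cells (Homo sapiens), read by MTT assay, with a stated time of 48 h (on this read-out higher numbers stand for weaker inhibition and lower numbers for stronger inhibition), compound 1 `CCOC(=O)CN(C)C(=O)c1ccc(C(CC)(CC)c2ccc(OCC(O)C(C)(C)C)c(C)c2)n1CC` gives 12200 nM. Compound 2 `C=CCN(C)C(=O)c1ccc(C(CC)(CC)c2ccc(OCC(O)C(C)(C)C)c(C)c2)n1CC` gives > 50000 nM, which is a limit of the assay and not a number. Its exact position is therefore unknown, and it can only be compared with that limit. For the measured compounds named here, only one measured step bears on the next change: an at least 4.0-fold higher number from compound 1 to compound 2 (0.61 log units; beyond the scatter), with vinyl in place of ethoxycarbonyl on a saturated chain carbon bound to an amide-type nitrogen.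

Compound 3 `CCn1c(C(=O)N(CCC#N)CCC#N)ccc1C(CC)(CC)c1ccc(OCC(O)C(C)(C)C)c(C)c1` keeps the shared core but changes the group on the carbonyl carbon, where allyl(methyl)amino leaves: a group of 9 heavy atoms (6 carbon, 3 nitrogen; no ring) in place of a group of 5 heavy atoms (4 carbon, 1 nitrogen; no ring), on a carbonyl carbon. The new group carries nitriles, which neither compound 1 nor compound 2 has, so the earlier step is only a loose guide. Still, compound 1 at 12200 nM shows that a different group on this amide nitrogen can bring a measurable number. A move toward stronger inhibition is therefore expected, though a modest one that may stay within the scatter. The estimated step is expected to be an at least 1.6-fold lower number from compound 2 to compound 3 (0.22 log units; that floor lies within the scatter). For compound 3, the estimated value is 30000 nM, with an expected range from 10000 nM to 50000 nM.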

Compound 3, half-maximal inhibitory concentration: 7100 nM
Estimate against measurement, compound 3: 4.2-fold (0.63 log units) above, and the stated range ends above it.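

In this assay, the change on this carbonyl carbon, from allyl(methyl)amino to the larger group bearing nitriles, gives an at least 7.0-fold lower number from compound 2 to compound 3 (0.84 log units; beyond the scatter), a step beyond the scatter that shows that a group with no ethoxycarbonyl can also bring a measurable number here. That step can be stated only as a floor because compound 2 has a limit and not a number: the limit of > 50000 nM in this assay, at which 1 of the 3 values shown sits. Set against the ester-bearing group, the nitrile-bearing group gives a 1.7-fold lower number from compound 1 to compound 3 (0.24 log units; within the scatter), which lies within the scatter, so these two quite different groups cannot be told apart on this read-out, and the ethoxycarbonyl group is not required for a measurable value at this position.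

The compounds shown leave open which feature of the new group matters, since it differs from allyl(methyl)amino in its nitriles, its size and its second chain all at once, and a group with a single nitrile-bearing chain on the same nitrogen would begin to separate these. Also open, as far as these compounds go, is how a carboxylic acid or a primary amine at the end of such a chain would read in this assay.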